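The compounds below may be only part of what the source reports. "The series", "measured", "known", "first", "only" and "open" are said of these compounds alone.

This study concerns four closely related compounds whose cores carry the same charged head group and differ in how an oxygen substituent is placed and capped. Compound 1 `C=C(C)C[N+](C)(C)c1ccccc1O` and compound 2 `C=C(C)C[N+](C)(C)c1cccc(O)c1` have the same atoms joined differently; the difference between their two cores is not broken down here. Compound 3 `C=C(C)C[N+](C)(C)c1ccccc1OC` arises from compound 1 by methyl in place of hydrogen on an oxygen on an aromatic ring, and compound 4 `C=C(C)C[N+](C)(C)c1cccc(OC)c1` arises from compound 2 by the same change, (methyl in place of hydrogen on an oxygen on an aromatic ring), the surroundings of the place being the same in both cases.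

All three measured compounds were tested in a functional assay with Cavia porcellus as the target; on this read-out higher numbers stand for weaker inhibition and lower numbers for stronger inhibition. In this assay compound 1 gives > 3000 nM, which is a limit of the assay rather than a number. Compound 2 likewise gives only a limit, > 3000 nM. Compound 3 gives > 3000 nM, again a limit. Consequently the change from compound 1 to compound 3 is a step that the two limits leave unreadable from compound 1 to compound 3: its size cannot be read, since (the limit of > 3000 nM in this assay, at which 3 of the 3 values shown sit).

Going by the values given here, for compound 4 the only anchor is compound 2, which in this assay gives > 3000 nM. Because (the limit of > 3000 nM in this assay, at which 3 of the 3 values shown sit), and because the same change left a step that the two limits leave unreadable from compound 1 to compound 3 from compound 1 to compound 3, the step is expected to be a step that the limit leaves unreadable from compound 2 to compound 4. Compound 4 is therefore estimated at 6000 nM, most probably reported once more as a limit, with a plausible range from 3000 nM to 30000 nM.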

Compound 4, half-maximal inhibitory concentration: > 3000 nM
Compound 4 gave a limit, no number (the forecaster's own chance of this, stated with the estimate: 85%); the middle value is on the limit's open side.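

In this assay compound 4 gives > 3000 nM, which is a limit and not a number. No step can be read from compound 2 to compound 4, because both compounds give only a limit: the limit of > 3000 nM in this assay, at which 4 of the 4 values shown sit. The compounds shown leave open how strongly any of the four inhibits, and whether going from hydroxy to methoxy changes the read-out at all.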